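A few compounds are considered here, and "the series" means these few. Any claim that something is new, unique, unknown or untested is made for them only; others in the source may bear on it.

Of the compounds shown here, two sharing one core have been measured in a functional assay on MCF7 cells (Homo sapiens) for antiproliferative activity, read by MTT assay, with a stated time of 48 h; on this read-out lower numbers stand for stronger inhibition and higher numbers for weaker inhibition. Compound 1 `O=c1cc(-n2cc(COc3ccccc3Br)nn2)c2cc(Br)ccc2o1` gives 28900 nM. Compound 2 `O=c1cc(-n2cc(COc3ccc(C(F)(F)F)cc3)nn2)c2cc(Br)ccc2o1` gives 11400 nM, the lower of the two numbers, and the gap to compound 1 is wider than the usual scatter. Compound 3 `O=c1cc(-n2cc(COc3ccc(F)cc3)nn2)c2cc(Br)ccc2o1` carries fluoro in place of trifluoromethyl on an aromatic carbon, a fluoro in place of trifluoromethyl on an aromatic carbon. Within the data shown here, no measured pair shows this change, so only a modest step, likely toward a somewhat higher number or none beyond the scatter, is expected: a 1.4-fold higher number from compound 2 to compound 3 (0.15 log units; within the scatter). Compound 3 is thus estimated at 16000 nM, within 5500 nM to 45000 nM.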

Compound 3, half-maximal inhibitory concentration: 7000 nM
Beside the measured number, compound 3's estimate is 2.3-fold (0.36 log units) above it; low and high end bracket the measured number.
By their numbers in this assay, from the lowest: compounds 3 and 2 (each within the scatter of the next); then compound 1.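

In this assay, fluoro in place of trifluoromethyl gives a 1.6-fold lower number from compound 2 to compound 3 (0.21 log units; within the scatter), so the two groups cannot be told apart at this position on the aromatic ring. Putting 4-fluorophenyl in place of 2-bromophenyl gives a 4.1-fold lower number from compound 1 to compound 3 (0.62 log units; beyond the scatter), a modest step, but one that stands clear of the scatter. Nothing available here explains either step. Going by these compounds, whether an amine or a methoxy group at this same position would give a number clearly different from those of compound 2 and compound 3 remains open.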